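The source may report more compounds than this note shows. Statements on the series, on what has been measured and on what is new or still open speak of the compounds shown alone.

Notes on the series around compound 1, `CC(C)(O/N=C(\C(=O)N[C@@H]1C(=O)N(S(=O)(=O)O)[C@@H]1CNC(=O)CN)c1csc(N)n1)C(=O)O`. In a physicochemical assay for metabolic stability, read by HPLC and mass spectrometry, in phosphate buffer, at 37 degrees C, at pH 7.4 (on this read-out lower numbers stand for a shorter-lived compound and higher numbers for a longer-lived compound), compound 1 gives 149 h, the lowest of the two plain numbers shown; compound 3, `CC(C)(O/N=C(\C(=O)N[C@@H]1C(=O)N(S(=O)(=O)O)[C@@H]1CN1CCCCC1=O)c1csc(N)n1)C(=O)O`, gives 214 h, a gap that stays within the scatter. Compound 2, `CC(C)(O/N=C(\C(=O)N[C@@H]1C(=O)N(S(=O)(=O)O)[C@@H]1CN1CCC1=O)c1csc(N)n1)C(=O)O`, reads > 1000 h in this assay, which is a limit of the measurement rather than a number. Compound 4, `CC(C)(O/N=C(\C(=O)N[C@@H]1C(=O)N(S(=O)(=O)O)[C@@H]1CN1CCNC1=O)c1csc(N)n1)C(=O)O`, is the next member to be run. Its difference from compound 1 is 2-oxoimidazolidin-1-yl in place of ((aminomethyl)carbonyl)amino on a saturated chain carbon bound to a saturated ring carbon. Cut one bond further out, the change reads (((aminomethyl)carbonyl)amino)methyl to (2-oxoimidazolidin-1-yl)methyl. For the measured compounds named here, two measured steps bear on it, each replacing the same ((aminomethyl)carbonyl)amino group at the same place: an at least 6.7-fold higher number from compound 1 to compound 2 (0.82 log units; beyond the scatter), where the value reached is the limit (the limit of > 1000 h in this assay, at which 1 of the 3 values shown sits), and a 1.4-fold higher number from compound 1 to compound 3 (0.16 log units; within the scatter). Between those two replacements, an at least 4.6-fold lower number from compound 2 to compound 3 (0.66 log units; beyond the scatter). The 2-oxoimidazolidin-1-yl of compound 4, a five-membered ring, sits between the 2-oxoazetidin-1-yl of compound 2 and the 2-oxopiperidin-1-yl of compound 3, so a rise beyond the scatter is expected, yet a smaller one than the step to compound 2. Compound 4 is therefore estimated at 320 h in this assay, within 150 h to 750 h. That estimate means an expected 2.1-fold higher number from compound 1 to compound 4 (0.33 log units; beyond the scatter).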

Compound 4, half-life: > 1000 h
Compound 4: no number, only a limit; the forecaster's own chance of this, stated with the estimate: 15%; middle value at least 3.1-fold (0.49 log units) away from the limit.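

The 2-oxoimidazolidin-1-yl group, on a saturated chain carbon bound to a saturated ring carbon, gives an at least 6.7-fold higher number from compound 1 to compound 4 (0.82 log units; beyond the scatter), and the same place also separates two ring groups, with an at least 4.6-fold higher number from compound 3 to compound 4 (0.66 log units; beyond the scatter). Compound 4 reads at a limit of this assay, not at a number, and this is the same limit that compound 2 reaches: the limit of > 1000 h in this assay, at which 2 of the 4 values shown sit. The 2-oxopiperidin-1-yl of compound 3 goes against any rule that a ring at this place is enough, since only compound 2 and compound 4 reach the limit, and the step from compound 2 to compound 4 cannot be read.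

From the compounds shown here alone, how far the true half-lives of compound 2 and compound 4 lie past the limit stays open, so no order of these two can be given. Also open, going by these compounds, is what a 2-oxopyrrolidin-1-yl group, a five-membered ring with carbon in place of the second ring nitrogen, would read at this place, which would show whether ring size or that nitrogen goes with the result for compound 4.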